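Quinoline amide series: fluoro for ethyl on the acid core

The source may hold more compounds than are shown below. What is called first, only, known or untested is meant among the compounds shown, and "the series" means these compounds.

Compound 1 `CCc1ccc2nc(C(=O)Nc3c(F)cc(-c4cccc(F)c4)cc3F)c(C)c(O)c2c1` gives 23.5% in a functional assay on Hep 3B2 cells (Homo sapiens) for antiproliferative activity, read by MTT assay, with a stated time of 24 h, tested at 1.23 ug/mL; a lower number here means a weaker effect, a higher number a stronger effect of the compound at the concentration tested. Compound 2 `Cc1c(C(=O)Nc2c(F)cc(-c3cccc(F)c3)cc2F)nc2ccc(F)cc2c1O` differs from compound 1 by fluoro in place of ethyl on an aromatic carbon; in this assay compound 2 gives 15.3%, a step of a number 8.2 percentage points lower from compound 1 to compound 2 (within the scatter). Compound 3 `CCc1ccc2nc(C(=O)Nc3c(F)cc(-c4cccc(F)c4)cc3F)c(C)c(C(=O)O)c2c1` carries a different core, differing from compound 1 by carboxy in place of hydroxy on an aromatic carbon; in this assay compound 3 gives 4.52%, the step being a number 19 percentage points lower from compound 1 to compound 3 (beyond the scatter). Compound 4 `Cc1c(C(=O)Nc2c(F)cc(-c3cccc(F)c3)cc2F)nc2ccc(F)cc2c1C(=O)O` is not yet measured and differs from compound 3 by fluoro in place of ethyl on an aromatic carbon, the same change as between compound 1 and compound 2, at the same place. Since the earlier step was a number 8.2 percentage points lower from compound 1 to compound 2 (within the scatter), the step from compound 3 to compound 4 is expected to be small, estimated as a number 2.5 percentage points lower from compound 3 to compound 4 (within the scatter). Compound 4 is therefore expected to give about 2% in this assay, most likely between -6% and 12%.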

Compound 4, a percentage reported as inhibition, at one concentration (the size of the read-out at that concentration, not a potency): 2.45%
The estimate for compound 4 lay 0.5 percentage points below the measured number, and the stated range covers the measured number.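

In this assay, fluoro in place of ethyl on the core of compound 3 gives a step that is a number 2.1 percentage points lower from compound 3 to compound 4 (within the scatter), and this agrees with the same change on the core of compound 1: the same change on two cores in this assay, a number 8.2 percentage points lower (within the scatter) from compound 1 to compound 2 and a number 2.1 percentage points lower (within the scatter) from compound 3 to compound 4, 6.1 percentage points apart, within the scatter of two such steps. Carboxy in place of hydroxy on the fluoro-bearing core gives a step that is a number 12.9 percentage points lower from compound 2 to compound 4 (beyond the scatter), and this agrees with the same change on the ethyl-bearing core: the same change on two cores in this assay, a number 19 percentage points lower (beyond the scatter) from compound 1 to compound 3 and a number 12.9 percentage points lower (beyond the scatter) from compound 2 to compound 4, 6.1 percentage points apart, within the scatter of two such steps. Both changes therefore carry across these four compounds, but since both fluoro steps lie within the scatter, this does not show that fluoro for ethyl has any effect, and a read-out at one concentration gives no potency.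

Open, on these data alone, is whether a longer chain or a methoxy group in place of ethyl, or an amine in place of hydroxy, would follow the same pattern. Also open, as far as these compounds go, is whether these steps would hold at other concentrations.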